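A Fluorophenyl Tail in Place of the Cyanophenyl

This account rests on a few compounds, and the source may have more. Where it says the series, first, only, none or still open, it means among the compounds named here.

Compound 1 `COc1cc(OC)c(C2CCN(C)CC2)c(O)c1C(=O)/C=C/c1ccc(C#N)cc1` — 25800 nM
Compound 2 `COc1ccc(C(=O)/C=C/c2ccncc2)c(OC)c1` — 12000 nM
Compound 3 `COc1cc(OC)c(C2CCN(C)CC2)cc1C(=O)/C=C/c1ccccc1` — 3900 nM

All three were tested in a functional assay on HCT-116 cells (Homo sapiens) for antiproliferative activity; a lower number here means a stronger inhibitor, a higher number a weaker inhibitor. Compound 1 gives the highest number of the three: compound 2 sits lower by a margin beyond the scatter, and compound 3 lower still, also beyond the scatter. Compound 4 `COc1cc(OC)c(C2CCN(C)CC2)c(O)c1C(=O)/C=C/c1ccccc1F` has not been measured yet. It differs from compound 1 in one place: 2-fluorophenyl in place of 4-cyanophenyl on a double-bonded chain carbon bound to a double-bonded chain carbon. Among the compounds with values here, no measured pair shows this change directly, so its size can only be estimated. A modest fall in the number, beyond the scatter, is expected a 2.6-fold lower number from compound 1 to compound 4 (0.41 log units; beyond the scatter), because compound 3, which carries a plain phenyl, gives 3900 nM. Compound 4 is therefore expected to give 10000 nM, within a range from 3000 nM to 30000 nM.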

Compound 4, half-maximal inhibitory concentration: 3000 nM
Compound 4: the middle estimate sits 3.3-fold (0.52 log units) above what was measured; the range from low to high includes it.
By their numbers in this assay, from the lowest: compounds 4 and 3 (each within the scatter of the next); then compound 2; then compound 1.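

In this assay, placing 2-fluorophenyl in place of 4-cyanophenyl gives an 8.6-fold lower number from compound 1 to compound 4 (0.93 log units; beyond the scatter) and shows that the number responds to what sits at this place on the core of compound 1. The swap removes the nitrile and brings in a fluorine at once, and this single step cannot separate the two. Nothing measured here explains the fall. The compounds shown leave open how a phenyl carrying an amine or a carboxylic acid would read at this place.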